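From compound 3 to compound 4: working notes

This account rests on a few compounds, and the source may have more. Where it says the series, first, only, none or still open, it means among the compounds named here.

Measured in a functional assay on MCF7 cells (Homo sapiens) for antiproliferative activity, read by MTT assay, with a stated time of 72 h (on this read-out lower numbers stand for stronger inhibition and higher numbers for weaker inhibition), each value a limit:
- compound 1 `C/C(=N\NC(=O)c1cccc(S(=O)(=O)N2CCOCC2)c1)c1cccc(O)c1`: > 100000 nM
- compound 2 `C/C(=N\NC(=O)c1cccc(S(=O)(=O)N2CCOCC2)c1)c1cc(O)ccc1O`: > 100000 nM
- compound 3 `O=C(N/N=C/c1ccco1)c1cccc(S(=O)(=O)N2CCOCC2)c1`: > 100000 nM

Among the compounds with values here, the series so far offers only (the limit of > 100000 nM in this assay, at which 3 of the 3 values shown sit). Compound 3 gives > 100000 nM, which is a limit and not a number, so its place among the others cannot be ranked.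

The next compound is compound 4 `O=C(N/N=C/c1cc(Br)ccc1O)c1cccc(S(=O)(=O)N2CCOCC2)c1`. The change is 5-bromo-2-hydroxyphenyl in place of furan-2-yl on a carbon with a double bond to nitrogen.

Within the data shown here, the one measured step that bears on it is a step that the two limits leave unreadable from compound 1 to compound 2, with hydroxy in place of hydrogen on an aromatic carbon. That step offers no size to carry over. Among the measured compounds shown here, no measured compound carries the 5-bromo-2-hydroxyphenyl group, and no measured step replaces furan-2-yl, so the data give no direct guide to this change.

The direction expected in this assay is towards stronger inhibition, held only weakly, and a further reading at the limit remains quite possible. The expected move is an at least 2.5-fold lower number from compound 3 to compound 4 (0.39 log units; beyond the scatter), an estimate with little support from the measured steps. For compound 4 the estimated value is 40000 nM, with an expected range of 8000 nM to 100000 nM.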

Compound 4, half-maximal inhibitory concentration: 26600 nM
Compound 4: middle estimate off by 1.5-fold (0.18 log units), on the high side; low and high end bracket the measured number.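

In this assay, the carbon with a double bond to nitrogen is the only place shown where a change yields a number rather than a limit: the limit of > 100000 nM in this assay, at which 3 of the 4 values shown sit.

The change to 5-bromo-2-hydroxyphenyl in place of furan-2-yl gives an at least 3.7-fold lower number from compound 3 to compound 4 (0.57 log units; beyond the scatter); this size is only a lower bound, as compound 3 stands at a limit, but it shows that this place can move the read-out on the shared core. The change replaces a five-membered aromatic ring with 1 hetero atom by a six-membered aromatic ring of carbon only, and it brings in bromine and a hydrogen-bond donor in the same step, so the shift cannot be assigned to any one of these parts.

Still open, on these data alone, is whether the bromine, the hydroxy or the carbon ring carries the shift, a question that a plain phenyl, a 5-chloro-2-hydroxyphenyl or a 5-bromo-2-methoxyphenyl at this place would address. Also open, as far as these compounds go, is how far the number can fall from here, for instance with an amine or a carboxylic acid on the ring in place of the bromine.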